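Configuration change at the ring carbon of compound 2

The source may report more compounds than this note shows. Statements on the series, on what has been measured and on what is new or still open speak of the compounds shown alone.

Compound 1 `C=C1[C@](C)(O)CC[C@@]1(C)c1ccc(C)cc1O` gives in a functional assay on HeLa cells (Homo sapiens) for cytotoxicity, read by MTT assay (on this read-out higher numbers stand for weaker inhibition and lower numbers for stronger inhibition), only a limit, > 10 ug/mL. Compound 2 `Cc1ccc([C@]2(C)CC[C@H](C(C)(C)O)O2)cc1` likewise gives only a limit in this assay, > 10 ug/mL. Among the compounds with values here, both values stand at the limit of > 10 ug/mL in this assay, at which 2 of the 2 values shown sit, so no step between measured compounds can be sized. Compound 3 `Cc1ccc([C@]2(C)CC[C@@H](C(C)(C)O)O2)cc1` differs from compound 2 only in configuration: the two compounds have the same atoms and bonds and differ only in configuration as drawn: 1 of 2 stereo elements differ; a stereocentre at a saturated ring carbon is drawn R in compound 2 and S in compound 3. With nothing to set a direction, the step that the limit leaves unreadable from compound 2 to compound 3 is expected to be none beyond the scatter. Compound 3 is expected to give 15 ug/mL in this assay, within 7 ug/mL to 40 ug/mL, most likely again reported as a limit.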

Compound 3, half-maximal inhibitory concentration: > 10 ug/mL
Compound 3 was reported as a limit (the forecaster's own chance of this, stated with the estimate: 85%); the middle value is on the limit's open side.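

Within the data shown here, no step from compound 2 to compound 3 can be read, as both results are limits and not numbers: the limit of > 10 ug/mL in this assay, at which 3 of the 3 values shown sit. The compounds shown leave open whether configuration at the saturated ring carbon matters in this assay.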